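Pyridyl sulfonamide series: moving the ring nitrogen

The compounds below may be only part of what the source reports. "The series", "measured", "known", "first", "only" and "open" are said of these compounds alone.

Measured so far in a functional assay on CHO-K1 cells for antagonist activity at prostaglandin E2 receptor EP1 subtype (Homo sapiens), read by FLIPR and calcium flux; a higher number here means a weaker inhibitor, a lower number a stronger inhibitor:
compound 1 `Cc1ccc(S(=O)(=O)N(CC(=O)NCc2ccc(Cl)cc2)c2cccnc2)cc1` gives < 1450 nM, which is a limit of the assay.
compound 2 `Cc1ccc(S(=O)(=O)N(CC(=O)NCc2ccc(Cl)cc2)c2cccnc2C)cc1` gives 676 nM.
compound 3 `Cc1ccc(S(=O)(=O)N(CC(=O)NCc2ccc(Cl)cc2)c2ccc(C)nc2)cc1` gives < 1450 nM, which is a limit of the assay.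

Compound 3 therefore stands only at a limit in this assay, and one further value of the three also sits at a limit; the limit of < 1450 nM in this assay, at which 2 of the 3 values shown sit, marks where the two of them sit. For the measured compounds named here, none of the measured steps can be read for size: the step that the limit leaves unreadable from compound 1 to compound 2, the step that the two limits leave unreadable from compound 1 to compound 3 and the step that the limit leaves unreadable from compound 2 to compound 3 all rest on at least one limit, and only compound 2 has a number.

Compound 4 `Cc1ccc(S(=O)(=O)N(CC(=O)NCc2ccc(Cl)cc2)c2cccc(C)n2)cc1` differs from compound 3 by 6-methylpyridin-2-yl in place of 6-methylpyridin-3-yl on a sulfonamide nitrogen, the two holding the same atoms joined differently. Going by the values given here, no measured step bears readably on this change, so no direction or size can be taken from the series for this assay.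

Among the compounds with values here, the expectation for compound 4 in this assay is therefore set near the only number available and its neighbouring limit: compound 4 is estimated at 1000 nM, within 300 nM to 3000 nM, which means an expected step that the limit leaves unreadable from compound 3 to compound 4 that may well again be reported only as a limit.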

Compound 4, inhibition constant: < 1450 nM
Compound 4 ended at the assay's limit (the forecaster's own chance of this, stated with the estimate: 50%); the middle value does not contradict the limit.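

In this assay compound 4 gives < 1450 nM, which is a limit of the assay, so none of its steps from compound 1, compound 2 or compound 3 can be read, and the values cluster at one point: the limit of < 1450 nM in this assay, at which 3 of the 4 values shown sit.

The compounds shown leave open whether 6-methylpyridin-2-yl in place of 6-methylpyridin-3-yl changes inhibition at all, and how compound 1, compound 3 and compound 4 stand against compound 2.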